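Methoxycarbonyl to propoxycarbonyl on compound 3

The source may report more compounds than this note shows. Statements on the series, on what has been measured and on what is new or still open speak of the compounds shown alone.

compound 1 `COC(=O)N1N=C(c2ccccc2)CC1c1cc(OC)c(OC)c(OC)c1`: 3950 nM
compound 2 `CCCOC(=O)N1N=C(c2ccccc2)CC1c1cc(OC)c(OC)c(OC)c1`: > 10000 nM (a limit)
compound 3 `COC(=O)N1N=C(c2ccc(OC)cc2)CC1c1cc(OC)c(OC)c(OC)c1`: 1710 nM

In a functional assay on HepG2 cells (Homo sapiens) for antiproliferative activity, read by MTT assay, with a stated time of 48 h (a lower number here means a stronger inhibitor of growth, a higher number a weaker inhibitor of growth), compound 3 gives 1710 nM, the lower of the two exact numbers. Compound 2 gives > 10000 nM, which is a limit of the assay. Compound 4 `CCCOC(=O)N1N=C(c2ccc(OC)cc2)CC1c1cc(OC)c(OC)c(OC)c1` carries propoxycarbonyl where compound 3 carries methoxycarbonyl: ethyl in place of hydrogen on a saturated chain carbon bound to an oxygen next to a carbonyl group. The same change was measured once, as an at least 2.5-fold higher number from compound 1 to compound 2 (0.40 log units; beyond the scatter). That step rests on (the limit of > 10000 nM in this assay, at which 1 of the 3 values shown sits). The other measured step, a 2.3-fold lower number from compound 1 to compound 3 (0.36 log units; beyond the scatter), is the methoxy change, which compound 3 and compound 4 share. Because of an at least 2.5-fold higher number from compound 1 to compound 2 (0.40 log units; beyond the scatter) a comparable or larger step toward a higher number is expected in this assay. The estimated step is a 3.5-fold higher number from compound 3 to compound 4 (0.55 log units; beyond the scatter). For compound 4 the expected value is 6000 nM, with an estimated range of 2800 nM to 14000 nM.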

Compound 4, concentration for 50% growth inhibition: > 10000 nM
Compound 4 ended at the assay's limit (the forecaster's own chance of this, stated with the estimate: 35%); middle value at least 1.6-fold (0.22 log units) from the limit.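

In this assay, the change from methoxycarbonyl to propoxycarbonyl also raises the number on the core of compound 3, with an at least 5.8-fold higher number from compound 3 to compound 4 (0.76 log units; beyond the scatter). The loss is therefore not confined to the core of compound 1: the same change on two cores in this assay, an at least 2.5-fold higher number (0.40 log units; beyond the scatter) from compound 1 to compound 2 and an at least 5.8-fold higher number (0.76 log units; beyond the scatter) from compound 3 to compound 4; the limit leaves it open whether they differ. The methoxy step can no longer be read on the propoxycarbonyl pair, as the step from compound 2 to compound 4 lies between two limits: the limit of > 10000 nM in this assay, at which 2 of the 4 values shown sit.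

From the compounds shown here alone, what ethoxycarbonyl or a carboxylic acid would give in this place stays open. Going by these compounds, how far compound 2 and compound 4 lie past the limit also stays open.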